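The source may report more compounds than this note shows. Statements on the series, on what has been measured and on what is new or still open speak of the compounds shown alone.

Of the compounds shown here, three that share one core have been measured in a functional assay on ACHN cells (Homo sapiens) for cytotoxicity, read by sulforhodamine B assay, with a stated time of 48 h, tested at 10 uM; a higher number here means a weaker effect of the compound at the concentration tested, a lower number a stronger effect. Compound 1 `COc1ccc(-c2cc(/C=C/C(=O)c3ccc(N)cc3)[nH]n2)cc1` gives 2%. Compound 2 `COc1cc(-c2cc(/C=C/C(=O)c3ccc(N)cc3)[nH]n2)cc(OC)c1OC` gives -61%, the lowest of the three numbers, and compound 3 `COc1cc(-c2cc(/C=C/C(=O)c3ccc(F)c(F)c3)[nH]n2)cc(OC)c1OC` gives 2%. Among the compounds with values here, the only step between measured compounds that differ in a single place lies on the carbonyl side of the molecule: a number 63 percentage points higher from compound 2 to compound 3 (beyond the scatter).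

Compound 4 `COc1ccc(-c2cc(/C=C/C(=O)c3ccc(N)cc3)[nH]n2)cc1OC` has not yet been measured. It differs from compound 2 by hydrogen in place of methoxy on an aromatic carbon. Within the data shown here, no measured step matches this change; the step from compound 2 to compound 3 alters a different part of the molecule and gives no direct guide. Compound 1 and compound 2 differ in more than one place, so only their two values can be set side by side, and the value of compound 1 lies well above that of compound 2. Compound 4 carries a methoxy group that compound 1 lacks, while lacking one that compound 2 carries. Compound 4 is therefore expected to land between the two, at about -30%, with a range of -65% to 5%. The expected step is a number 31 percentage points higher from compound 2 to compound 4 (beyond the scatter), beyond the scatter but uncertain in size.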

Compound 4, a percentage reported as activity, at one concentration (the size of the read-out at that concentration, not a potency): -82%
Beside the measured number, compound 4's estimate is 52 percentage points above it, outside the stated range (below it).
By their numbers in this assay, from the lowest: compound 4; then compound 2; then compounds 1 and 3 (each within the scatter of the next).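

In this assay the new result shows that the effect of a methoxy group on this aromatic ring depends on what else the ring carries. Methoxy in place of hydrogen gives a number 84 percentage points lower from compound 1 to compound 4 (beyond the scatter) while hydrogen in place of methoxy gives a number 21 percentage points lower from compound 2 to compound 4 (beyond the scatter) so both changes lead to compound 4, and the first is much the larger. More methoxy groups therefore do not simply mean a lower number, since compound 4 carries one fewer than compound 2 and still has the lowest number of the compounds shown.

From the compounds shown here alone, whether a hydroxyl group, an ethoxy group or a chlorine atom at this position would lower the number further remains open, as does whether the same methoxy change would act alike with the 3,4-difluorophenyl group on the carbonyl carbon. Nothing shown here accounts for these steps.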